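Triazole hydroxamates: aryl swap at the ring carbon

The compounds below may be only part of what the source reports. "The series", "measured", "known", "first", "only" and "open" are said of these compounds alone.

Measured so far:
compound 1 `COc1ccc(-n2nc(-c3ccc(O)cc3)nc2CNc2ccc(C(=O)NO)cc2)cc1` — 102 nM
compound 2 `O=C(NO)c1ccc(NCc2nc(-c3ccc(Cl)cc3)nn2-c2ccccc2)cc1` — 181 nM
compound 3 `O=C(NO)c1ccc(NCc2nc(-c3cccs3)nn2-c2ccc(O)cc2)cc1` — 33.5 nM

In an assay on Sf9 cells for inhibition of protein deacetylase HDAC6 (Homo sapiens), read by fluorescence, with a stated time of 40 min (on this read-out higher numbers stand for weaker inhibition and lower numbers for stronger inhibition), compound 2 stands at the highest of the three numbers. Compound 1 sits within the scatter of compound 2, so no order between them is claimed. Compound 3 gives a number beyond the scatter below compound 2, so compound 3 is the only one of the three clearly apart from it.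

Compound 4 `Cc1ccsc1-c1nc(CNc2ccc(C(=O)NO)cc2)n(-c2ccccc2)n1` is not yet measured. It differs from compound 2 in one place: 3-methylthiophen-2-yl in place of 4-chlorophenyl on an aromatic carbon. Going by the values given here, no pair of measured compounds shows this change, so its size cannot be read from the data. The change is expected to move the number of compound 4 in this assay somewhat lower than compound 2, as the step of a 1.8-fold lower number from compound 2 to compound 4 (0.26 log units; within the scatter) means, though the expected shift may fall inside the scatter. The estimate for compound 4 is 100 nM, with a range from 40 nM to 250 nM.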

Compound 4, half-maximal inhibitory concentration: 30.7 nM
Beside the measured number, compound 4's estimate is 3.3-fold (0.51 log units) above it; measured number below the stated range.
By their numbers in this assay, from the lowest: compounds 4 and 3 (each within the scatter of the next); then compounds 1 and 2 (each within the scatter of the next).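

In this assay the first step readable at this position runs a 5.9-fold lower number from compound 2 to compound 4 (0.77 log units; beyond the scatter). The group on the aromatic carbon between two ring nitrogen atoms therefore matters to the read-out: with the rest of the molecule unchanged, 3-methylthiophen-2-yl in place of 4-chlorophenyl moves the number beyond the scatter. Nothing available explains this shift. On these data alone, whether the step belongs to the methyl group or to the ring swap itself remains open. As far as these compounds go, the response to a pyridyl ring or a carboxylic acid on this carbon also remains open.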